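A few compounds are considered here, and "the series" means these few. Any claim that something is new, unique, unknown or untested is made for them only; others in the source may bear on it.

Compound 1, `O=C(/N=C1\NC2(CCCCO2)CCS1)Nc1ccccc1`: in a functional assay on the whole organism (strain CF-1) with Mus musculus as the target, in the writhing test, with a stated time of 15 min (a lower number here means that less compound is needed, a higher number that more compound is needed for the effect), compound 1 gives > 200 mg/kg, which is a limit of the assay and not a number.
Compound 2, `COc1ccc(C(=O)/N=C2\NC3(CCCCO3)CCS2)cc1`: in this assay compound 2 gives 62 mg/kg.

Compound 2 therefore stands as the only compound with a numerical result in this assay; the second result shown is the limit of > 200 mg/kg in this assay, at which 1 of the 2 values shown sits, and nothing more can be read from it. Compound 3, `O=C(/N=C1\NC2(CCCCO2)CCS1)c1ccc(Cl)cc1`, differs from compound 2 only at the aromatic ring: chloro in place of methoxy on an aromatic carbon. Among the measured compounds shown here, no step between two measured compounds is available to guide this change, so the expected step in this assay from compound 2 to compound 3 is one that does not go beyond the usual scatter in either direction, as the estimate a 1.0-fold lower number from compound 2 to compound 3 (0.01 log units; within the scatter) expresses. On that basis compound 3 is expected to give about 60 mg/kg, estimated to lie between 25 mg/kg and 150 mg/kg.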

Compound 3, dose for half-maximal effect: 1.1 mg/kg
Compound 3: middle estimate off by 55-fold (1.74 log units), on the high side, and the stated range ends above it.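

In this assay, this place on the aromatic ring, para to a large group, proves highly sensitive to what it carries: chloro in place of methoxy gives a 56-fold lower number from compound 2 to compound 3 (1.75 log units; beyond the scatter). The compounds with the 4-chlorophenyl group and the anilino group on the carbonyl carbon are also far apart, with an at least 180-fold lower number from compound 1 to compound 3 (2.25 log units; beyond the scatter). The size of that second step is bounded only, since the result for compound 1 is a limit of the assay and not a number: the limit of > 200 mg/kg in this assay, at which 1 of the 3 values shown sits.

The compounds shown leave open whether the lower number is particular to chloro or would also appear with fluoro, bromo or trifluoromethyl at this place. They also leave open what an amine or a carboxylic acid there would do, and how chloro would fare elsewhere on the ring.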